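This account rests on a few compounds, and the source may have more. Where it says the series, first, only, none or still open, it means among the compounds named here.

Of the compounds shown here, three sharing one core have been measured in a functional assay on NCI-H1650 cells (Homo sapiens) for cytotoxicity, read by MTT assay, with a stated time of 48 h; on this read-out lower numbers stand for stronger inhibition and higher numbers for weaker inhibition. Compound 1 `CC(C)COc1ccc2c(Cl)ccnc2c1` gives 2100 nM. Compound 2 `CCCCCCOc1ccc2c(Cl)ccnc2c1` gives 2080 nM. Compound 3 `Clc1ccnc2cc(OCc3ccccc3)ccc12` gives 2720 nM. The three numbers sit close together: the step of a 1.0-fold lower number from compound 1 to compound 2 (0.00 log units; within the scatter), the step of a 1.3-fold higher number from compound 1 to compound 3 (0.11 log units; within the scatter) and the step of a 1.3-fold higher number from compound 2 to compound 3 (0.12 log units; within the scatter) all stay inside the scatter of repeated measurements, so compound 2 cannot be told apart from the other two on these numbers.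

Compound 4 `Clc1ccnc2cc(OCCc3ccccc3)ccc12` has not yet been measured in this assay. Its difference from compound 2 is phenyl in place of butyl on a saturated chain carbon, two bonds along the chain from an oxygen on an aromatic ring. The measured step that bears most directly on this change is the one in which a phenyl replaces a pentyl, and it was within the scatter; the swap of isopropyl for pentyl was also within the scatter. Within the data shown here, nothing among the measured compounds points to a step beyond the scatter, so compound 4 is expected to give 2400 nM in this assay, within a range from 1200 nM to 4800 nM. The expected step of a 1.2-fold higher number from compound 2 to compound 4 (0.06 log units; within the scatter) is therefore estimated to be small.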

Compound 4, half-maximal inhibitory concentration: 2300 nM
Compound 4: the middle estimate sits 1.0-fold (0.02 log units) above what was measured; the measured number falls inside the stated range.
By their numbers in this assay, from the lowest: compounds 2, 1, 4 and 3 (each within the scatter of the next).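

With phenyl in place of butyl on a saturated chain carbon, two bonds along the chain from an oxygen on an aromatic ring, this assay gives a 1.1-fold higher number from compound 2 to compound 4 (0.04 log units; within the scatter) and so does not tell the two compounds apart. The earlier compounds shown here showed such a swap only on a saturated chain carbon bound to the oxygen, as a 1.3-fold higher number from compound 2 to compound 3 (0.12 log units; within the scatter) and this result shows that a phenyl placed two bonds along the chain also leaves the number within the scatter. No supporting measurement is available to explain why these numbers stay so close.

All the groups on the oxygen shown so far are built of carbon and hydrogen alone. On these data alone, whether an amine or a carboxylic acid on this chain would move the number beyond the scatter remains open.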